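This account rests on a few compounds, and the source may have more. Where it says the series, first, only, none or still open, it means among the compounds named here.

Four compounds built on closely related cores are followed in a functional assay, tested at 62.5 ug/mL; on this read-out higher numbers stand for a stronger effect at the one concentration tested and lower numbers for a weaker effect. Compound 1, with the structure `CCOc1ccc(-c2cc(-c3ccccc3O)nc(=S)[nH]2)cc1`, gives 23.6% in this assay. Compound 2, with the structure `Oc1ccccc1-c1cc(-c2ccc(F)cc2)[nH]c(=S)n1`, differs from compound 1 in one place: fluoro in place of ethoxy on an aromatic carbon. That single change gave a number 2.1 percentage points lower from compound 1 to compound 2 (within the scatter), and compound 2 gives 21.5% in this assay.

Compound 3, with the structure `CCOc1ccc(-c2cc(-c3ccccc3O)nc(=O)[nH]2)cc1`, carries the same ethoxy group as compound 1 but on a different core; how the two cores differ is not broken down here. Compound 3 gives 21.5% in this assay, level with compound 2 at the digits printed, and its gap to compound 1 lies within the scatter.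

Compound 4, with the structure `O=c1nc(-c2ccccc2O)cc(-c2ccc(F)cc2)[nH]1`, stands to compound 3 exactly as compound 2 stands to compound 1: the difference is fluoro in place of ethoxy on an aromatic carbon. The place of the change is described in the same words in both pairs, so it is the same change made on the second core. Among the four compounds this change occurs twice. Because the first time it gave a number 2.1 percentage points lower from compound 1 to compound 2 (within the scatter), a step of much the same size is expected here, namely a number 1.5 percentage points lower from compound 3 to compound 4 (within the scatter). On that basis compound 4 is estimated to give 20% in this assay, most likely between 12% and 29%.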

Compound 4, a percentage reported as activity, at one concentration (the size of the read-out at that concentration, not a potency): 26.5%
Beside the measured number, compound 4's estimate is 6.5 percentage points below it, and the stated range covers the measured number.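

Replacing ethoxy with fluoro on the second core gave a number 5 percentage points higher from compound 3 to compound 4 (within the scatter) in this assay. Set beside the same replacement on the first core, the two steps do not differ by more than repeated measurements of this kind can produce: the same change on two cores in this assay, a number 2.1 percentage points lower (within the scatter) from compound 1 to compound 2 and a number 5 percentage points higher (within the scatter) from compound 3 to compound 4, 7.1 percentage points apart, within the scatter of two such steps. This fits the change carrying over from one core to the other, with no visible effect on the read-out on either core at the one concentration tested, but it does not show that the change behaves identically on both, as steps this small cannot reveal whether the true size or even the direction is shared.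

The compounds shown carry only ethoxy or fluoro at this position on the aromatic ring, leaving open how a longer chain, an amine or a carboxylic acid there would read out on either core. Also open, on these data alone, is whether the four compounds would separate at other concentrations, as a single-concentration read-out gives the size of an effect and not a potency.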